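Swapping Methylsulfanyl for Trifluoromethyl on the Phenyl Ring

The source may report more compounds than this note shows. Statements on the series, on what has been measured and on what is new or still open speak of the compounds shown alone.

Compound 1 `CN(C)C(=O)c1cccnc1NCCCN1CCN(c2ccccc2OC(F)(F)F)CC1` gives 100 nM in a functional assay on aorta for antagonist activity at Alpha-1D adrenergic receptor (Rattus norvegicus); a higher number here means weaker binding, a lower number tighter binding.
Compound 2 `Cc1ccccc1N1CCN(CCCNc2ncccc2C(=O)N(C)C)CC1` gives 10 nM in this assay.
Compound 3 `CSc1ccccc1N1CCN(CCCNc2ncccc2C(=O)N(C)C)CC1` gives 31.6 nM in this assay.

All three share one core and differ only in the group on an aromatic carbon. Compound 3 stands second highest of the three numbers: a 3.2-fold higher number from compound 2 to compound 3 (0.50 log units; beyond the scatter), while a 3.2-fold lower number from compound 1 to compound 3 (0.50 log units; beyond the scatter). Compound 4 `CN(C)C(=O)c1cccnc1NCCCN1CCN(c2ccccc2C(F)(F)F)CC1` has not yet been measured. It differs from compound 3 in one place: trifluoromethyl in place of methylsulfanyl on an aromatic carbon. Going by the values given here, no measured step swaps exactly these two groups, so the comparison is indirect. Among the compounds with values here, the steps that bear on it are a 3.2-fold lower number from compound 1 to compound 3 (0.50 log units; beyond the scatter) and a 10-fold lower number from compound 1 to compound 2 (1.00 log units; beyond the scatter), both of which place the compound carrying the trifluoromethoxy group at the highest number. Trifluoromethyl is, by name and make-up, nearer to trifluoromethoxy than to methyl or methylsulfanyl, so a modest rise from compound 3 toward compound 1 is expected, though it may be small. The step that is expected here is a 1.9-fold higher number from compound 3 to compound 4 (0.28 log units; within the scatter). Compound 4 is therefore estimated at 60 nM, with a range from 20 nM to 200 nM.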

Compound 4, dissociation constant: 316 nM
For compound 4 the middle estimate is 5.3-fold (0.72 log units) below the measured one, and the stated range ends below it.
By their numbers in this assay, from the lowest: compound 2; then compound 3; then compound 1; then compound 4.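

In this assay, this position spans a wider range than the first three compounds showed: putting trifluoromethyl in place of methylsulfanyl gives a 10-fold higher number from compound 3 to compound 4 (1.00 log units; beyond the scatter), and putting it in place of methyl gives a 32-fold higher number from compound 2 to compound 4 (1.50 log units; beyond the scatter), so compound 4 is the weakest binder of the four. The two fluorine-bearing groups are not interchangeable here either, as trifluoromethyl in place of trifluoromethoxy gives a 3.2-fold higher number from compound 1 to compound 4 (0.50 log units; beyond the scatter). Across these four compounds, the fluorine-bearing groups hold the two highest numbers and methyl and methylsulfanyl the two lowest, with no compound going against that pattern.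

On these data alone, what an amine, a hydroxyl or a chlorine atom would give on this same carbon stays open. So does whether this order of groups would survive a longer chain in the shared core. Nothing available here accounts for these differences.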